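Fluoro in place of hydrogen: working notes

The compounds below may be only part of what the source reports. "The series", "measured", "known", "first", "only" and "open" are said of these compounds alone.

In a functional assay on HeLa cells (Homo sapiens) for inhibition (a higher number here means a weaker inhibitor, a lower number a stronger inhibitor), compound 1 `O=C1O/C(=C\Cn2ccc(=O)[nH]c2=O)C(OCc2ccccc2)=C1OCc1ccccc1` gives 50000 nM and compound 2 `O=C1O/C(=C\Cn2cnc3c(-n4cccc4)ncnc32)C(OCc2ccccc2)=C1OCc1ccccc1` gives 70000 nM as its value. Among the measured compounds shown here, these two numbers lie within the scatter of each other, so compound 1 stands level with the only other measured compound.

Compound 3 `O=C1O/C(=C\Cn2cc(F)c(=O)[nH]c2=O)C(OCc2ccccc2)=C1OCc1ccccc1` keeps the core of compound 1 and differs in one place fluoro in place of hydrogen on an aromatic carbon with fluoro in place of hydrogen on an aromatic carbon. For the measured compounds named here, no measured pair isolates this change, so any expectation is a judgement with wide uncertainty. In this assay a move toward a stronger inhibitor, beyond the scatter, is expected, though no change cannot be excluded. The estimated 4.2-fold lower number from compound 1 to compound 3 (0.62 log units; beyond the scatter) is therefore only tentative. For compound 3 the estimated value is 12000 nM with an expected range from 1500 nM to 60000 nM in this measurement.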

Compound 3, half-maximal inhibitory concentration: 40000 nM
Compound 3: middle estimate off by 3.3-fold (0.52 log units), on the low side; low and high end bracket the measured number.
By their numbers in this assay, from the lowest: compounds 3, 1 and 2 (each within the scatter of the next).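

In this assay, fluoro in place of hydrogen on an aromatic carbon gives a 1.3-fold lower number from compound 1 to compound 3 (0.10 log units; within the scatter) and so leaves compound 3 level with compound 1. Among the compounds shown here, this is the first single-place step, and it shows that a fluoro group at this position of the six-membered aromatic ring with 2 nitrogen, on the shared core, gives a value in the same range as hydrogen does. The data offer nothing that would explain this result at the level of the fluoro group or of the position it occupies.

Still open, from the compounds shown here alone, is whether a group other than fluoro at this same position, such as methyl, trifluoromethyl or an amine, would give a step beyond the scatter. Also open, going by these compounds, is whether the same exchange would read alike on a compound in which a carboxylic acid or a longer chain replaces a benzyl ether.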